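The source may hold more compounds than are shown below. What is called first, only, known or untested is meant among the compounds shown, and "the series" means these compounds.

For the measured compounds named here, in an ADME assay on MDCK cells (Canis lupus familiaris) for cytotoxicity, read by MTT assay, with a stated time of 48 h (on this read-out higher numbers stand for lower toxicity in this test and lower numbers for higher toxicity in this test), two members have numbers so far: compound 1 `Fc1ccc(-c2cn(CC3=C(Cl)c4ccc(-c5cccs5)nc4CC3)nn2)c(F)c1` gives 188 ug/mL and compound 2 `FC(F)(F)c1cc(-c2cn(CC3=C(Cl)c4ccc(-c5cccs5)nc4CC3)nn2)cc(C(F)(F)F)c1` gives 35 ug/mL on the same shared core. Compound 1 holds the higher of the two numbers, and the gap down to compound 2 lies beyond the usual scatter. Compound 3 `CCCCCc1cn(CC2=C(Cl)c3ccc(-c4cccs4)nc3CC2)nn1` has no number yet. It departs from compound 1 by pentyl in place of 2,4-difluorophenyl on an aromatic carbon of the five-membered aromatic ring with 3 nitrogen (pentyl in place of 2,4-difluorophenyl on an aromatic carbon), so a group with a ring gives way to one with no ring. Going by the values given here, no measured compound carries a chain at this place, and the data offer no direct guide. Compound 1 at 188 ug/mL sits at the top of a very short range, which makes a move down in this assay the likelier direction, of moderate size and only a little beyond the scatter. The expected change is a 2.4-fold lower number from compound 1 to compound 3 (0.37 log units; beyond the scatter) on this estimate. Compound 3 is expected at 80 ug/mL with an estimated range from 25 ug/mL to 250 ug/mL as the working figure.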

Compound 3, half-maximal cytotoxic concentration: 50 ug/mL
Compound 3: middle estimate off by 1.6-fold (0.20 log units), on the high side, within the range that was stated.
By their numbers in this assay, from the lowest: compounds 2 and 3 (each within the scatter of the next); then compound 1.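

In this assay, this first step at the aromatic carbon of the five-membered aromatic ring with 3 nitrogen shows that the number responds to the group placed there: pentyl in place of 2,4-difluorophenyl gives a 3.8-fold lower number from compound 1 to compound 3 (0.58 log units; beyond the scatter), a modest change. Compound 2 at 35 ug/mL and compound 3 at 50 ug/mL lie within the scatter of each other, so among these three compounds a group with a ring and a group with no ring can give numbers in the same low band, and only compound 1 stands clear of that band. No measured property bears on this step, and the data give no cause for it.

The compounds shown do not separate the loss of the ring from the loss of the fluorine, a question that a plain phenyl at this place would address. They also leave open how the number runs with the chain itself, as a propyl, a longer chain or a pentyl chain ending in an amine at this place would show.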